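Thioester in Place of Methyl Ester on a Lipophilic Diene Chain

A few compounds are considered here, and "the series" means these few. Any claim that something is new, unique, unknown or untested is made for them only; others in the source may bear on it.

Compound 1, `COC(=O)/C=C(C)/C=C/CC(C)CCCC(C)C`: 6.2
Compound 2, `COC(=O)/C=C(C)/C=C/CC(C)CCCC(C)(C)OC`: 5
Compound 3, `C#CCCOC(=O)/C=C(C)/C=C/CC(C)CCCC(C)(C)OC`: 5.2

In a physicochemical assay for lipophilicity (a higher number here means a more lipophilic compound, a lower number a more polar compound), compound 1 gives 6.2, the highest of the three numbers; compound 3 lies nearest at 5.2 and compound 2 furthest at 5. The two measured steps run in opposite directions: a number 1.20 log units lower from compound 1 to compound 2 (beyond the scatter), while a number 0.20 log units higher from compound 2 to compound 3 (within the scatter).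

Compound 4, `CCSC(=O)/C=C(C)/C=C/CC(C)CCCC(C)C`, is not yet measured. It differs from compound 1 in one place: ethylsulfanyl in place of methoxy on a carbonyl carbon. Going by the values given here, no measured pair changes anything at the carbonyl carbon, and none brings in sulfur. The step from compound 2 to compound 3 is the only one that touches the ester side, and it was small. The change to compound 4 adds a heavy atom and exchanges oxygen for sulfur, so an upward step beyond the scatter is expected, estimated as a number 0.80 log units higher from compound 1 to compound 4 (beyond the scatter). Compound 4 is therefore expected to come in at 7, with a range from 6.4 to 7.6.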

Compound 4, partition coefficient: 7.98
Beside the measured number, compound 4's estimate is 0.98 log units below it; measured number outside the range, above it.
By their numbers in this assay, from the lowest: compounds 2 and 3 (each within the scatter of the next); then compound 1; then compound 4.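

In this assay, ethylsulfanyl in place of methoxy on a carbonyl carbon gives a number 1.78 log units higher from compound 1 to compound 4 (beyond the scatter). Going by these compounds alone, the only earlier change on the ester side, a number 0.20 log units higher from compound 2 to compound 3 (within the scatter), did not leave the scatter, so this is the first change on that side to move the number beyond it, and the first measured change at the carbonyl carbon itself. Nothing on hand accounts for the size of this step.

The compounds shown leave open how the step divides between the sulfur and the added carbon; an ethoxy group and a methylsulfanyl group on a carbonyl carbon would be the comparisons that separate the two. Also open, on these data alone, is whether a step of this size would recur on the chain of compound 2, or with an amide on the carbonyl carbon.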